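The source may hold more compounds than are shown below. What is called first, only, known or untested is meant among the compounds shown, and "the series" means these compounds.

Measured so far in an ADME assay on microsomes from liver (Rattus norvegicus) for metabolic stability; a lower number here means that the compound disappears faster, a higher number that the compound lasts longer:
- compound 1 `COc1cc(OCc2cccc(-c3ccc(OC)nc3)c2)c2cc(-c3cn4nc(OC)sc4n3)oc2c1`: 0.633 h
- compound 2 `COc1cc(OCc2csc(-c3ccc(C(C)(C)O)cc3)n2)c2cc(-c3cn4nc(OC)sc4n3)oc2c1`: 1.15 h

Compound 2 lies within the usual scatter of compound 1, so these two values cannot be told apart. Compound 3 `COc1cc(OCc2csc(-c3ccccc3)n2)c2cc(-c3cn4nc(OC)sc4n3)oc2c1` differs from compound 2 by hydrogen in place of 1-hydroxy-1-methylethyl on an aromatic carbon, with hydrogen in place of 1-hydroxy-1-methylethyl on an aromatic carbon. Among the measured compounds shown here, no measured pair differs in one place only, so there is no direct guide to the size of this step. A modest fall in this assay is expected, possibly no larger than the scatter. The expected step is a 1.6-fold lower number from compound 2 to compound 3 (0.22 log units; within the scatter). For compound 3 the estimated half-life is 0.7 h, with an expected range of 0.3 h to 1.5 h.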

Compound 3, half-life: 1.22 h
For compound 3 the middle estimate is 1.7-fold (0.24 log units) below the measured one; measured number inside the range.
By their numbers in this assay, from the lowest: compounds 1, 2 and 3 (each within the scatter of the next).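

Replacing 1-hydroxy-1-methylethyl with hydrogen on the six-membered aromatic ring gives, in this assay, a 1.1-fold higher number from compound 2 to compound 3 (0.03 log units; within the scatter) and so leaves no readable difference in half-life. Among the compounds shown here, this is the first step here that differs in one place only, and it shows that this position tolerates the loss of the whole group in this assay. No available evidence bears on this result.

Going by these compounds, whether another group at this position, such as an amine or a carboxylic acid, would move the half-life beyond the scatter remains open. Also open, on these data alone, is whether the same exchange would have so little effect with a different group in place of the thiazole-bearing side chain's neighbours on the shared core.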